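The source may hold more compounds than are shown below. What is called first, only, known or untested is meant among the compounds shown, and "the series" means these compounds.

Measured compounds: compound 1, `O=C(COc1cccc2ccccc12)N/N=C/c1ccc(Br)cc1`, 106 ug/mL; compound 2, `O=C(COc1cccc2ccccc12)N/N=C/c1ccccc1O`, 5.19 ug/mL; compound 3, `C/C(=N\NC(=O)COc1cccc2ccccc12)c1ccccc1O`, 11.3 ug/mL.

In an ADME assay on MT4 cells (Homo sapiens) for cytotoxicity, read by MTT assay, with a stated time of 4 days (on this read-out lower numbers stand for higher toxicity in this test and higher numbers for lower toxicity in this test), compound 2 gives 5.19 ug/mL, and the change 4-bromophenyl in place of 2-hydroxyphenyl on a carbon with a double bond to nitrogen produces a 20-fold higher number from compound 2 to compound 1 (1.31 log units; beyond the scatter). Compound 3 and compound 2 share the same right-hand group; the difference between their two cores is not broken down here, and in this assay compound 3 gives 11.3 ug/mL. Compound 4, `C/C(=N\NC(=O)COc1cccc2ccccc12)c1ccc(Br)cc1`, has not yet been measured. It carries the same kind of change as compound 1, (4-bromophenyl in place of 2-hydroxyphenyl on a carbon with a double bond to nitrogen), though here the carbon with the double bond to nitrogen also bears a saturated chain carbon. Because a 20-fold higher number from compound 2 to compound 1 (1.31 log units; beyond the scatter) was large, a step of similar direction, an 11-fold higher number from compound 3 to compound 4 (1.03 log units; beyond the scatter), is expected for compound 4. Compound 4 is therefore estimated at 120 ug/mL in this assay, with a range from 45 ug/mL to 300 ug/mL.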

Compound 4, half-maximal cytotoxic concentration: 77.6 ug/mL
Compound 4: the middle estimate sits 1.5-fold (0.19 log units) above what was measured; the measured number falls inside the stated range.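

In this assay the change from 2-hydroxyphenyl to 4-bromophenyl, on a carbon with a double bond to nitrogen that also bears a saturated chain carbon, gives a 6.9-fold higher number from compound 3 to compound 4 (0.84 log units; beyond the scatter) and keeps the direction seen on the other core. The direction therefore carries from one core to the other, but the size does not carry over intact: the same change on two cores in this assay, a 20-fold higher number (1.31 log units; beyond the scatter) from compound 2 to compound 1 and a 6.9-fold higher number (0.84 log units; beyond the scatter) from compound 3 to compound 4, 3.0-fold (0.47 log units) apart, beyond the scatter of two such steps. For the compounds shown here, with only two cores, this does not show what sets the size of the step or how it would behave on a further core.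

The compounds shown leave open whether a longer chain in place of the saturated chain carbon would shift the step again. They also leave open how an amine or a carboxylic acid would compare with 4-bromophenyl at that place.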